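The source may hold more compounds than are shown below. What is called first, only, known or untested is meant among the compounds shown, and "the series" means these compounds.

- compound 1 `O=S(=O)(CCO)c1cccc(-c2ccc3nccc(-c4ccncc4)c3n2)c1` gives 26000 nM
- compound 2 `CS(=O)(=O)Nc1cccc(-c2ccc3nccc(-c4ccncc4)c3n2)c1` gives 13000 nM

In an ADME assay on CHO cells (Cricetulus griseus) for cytotoxicity, read by MTT assay (a lower number here means a stronger inhibitor, a higher number a weaker inhibitor), compound 2 lies within the scatter of compound 1, so neither can be ranked above the other. Compound 3 `CS(=O)(=O)c1cccc(-c2ccc3nccc(-c4ccncc4)c3n2)c1` brings the change methylsulfonyl in place of methanesulfonamido on an aromatic carbon or, in words, methylsulfonyl in place of methanesulfonamido on an aromatic carbon. Within the data shown here, the only measured step that bears on this, a 2.0-fold lower number from compound 1 to compound 2 (0.30 log units; within the scatter) and also a swap of the group at this place, gives no sign of a large effect. No change beyond the scatter is therefore expected in this assay here. The estimated step is a 1.4-fold higher number from compound 2 to compound 3 (0.14 log units; within the scatter) and so stays small. Compound 3 is expected at 18000 nM with an estimated range of 7000 nM to 45000 nM for this measurement.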

Compound 3, half-maximal inhibitory concentration: 13000 nM
For compound 3 the middle estimate is 1.4-fold (0.14 log units) above the measured one; measured number inside the range.
By their numbers in this assay, from the lowest: compounds 2, 3 and 1 (each within the scatter of the next).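

In this assay the step of no change at the digits printed from compound 2 to compound 3 (within the scatter) shows that methylsulfonyl can stand in for methanesulfonamido on this aromatic carbon, without its hydrogen-bond donor, and the number stays within the scatter. Removing the hydroxymethyl end of the sulfonyl side chain gives a 2.0-fold lower number from compound 1 to compound 3 (0.30 log units; within the scatter) and so also leaves the number within the scatter. Nothing available here explains these readings.

The compounds shown leave open whether an amine, a carboxylic acid or a longer chain on this carbon would move the number beyond the scatter.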